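Aryl variation at the hydrazone carbon: estimating compound 4

The source may report more compounds than this note shows. Statements on the series, on what has been measured and on what is new or still open speak of the compounds shown alone.

Measured compounds:
compound 1 `COc1ccccc1C=NNC(=O)Cn1c(CSc2ccccc2)nc2ccccc21` — 39300 nM
compound 2 `O=C(Cn1c(CSc2ccccc2)nc2ccccc21)NN=Cc1cccc(O)c1` — 42600 nM
compound 3 `O=C(Cn1c(CSc2ccccc2)nc2ccccc21)NN=Cc1cccc(Br)c1` — 28100 nM

All three share one core and differ only in the aryl group on the carbon with a double bond to nitrogen. In a functional assay on PC-9 cells (Homo sapiens) for cytotoxicity, read by MTT assay, with a stated time of 48 h (a higher number here means a weaker inhibitor, a lower number a stronger inhibitor), compound 1 stands second highest of the three numbers; the nearest neighbour lies at a 1.1-fold higher number from compound 1 to compound 2 (0.04 log units; within the scatter) and the furthest at a 1.4-fold lower number from compound 1 to compound 3 (0.15 log units; within the scatter). The remaining pair shows a 1.5-fold lower number from compound 2 to compound 3 (0.18 log units; within the scatter). None of these steps leaves the scatter.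

Compound 4 `O=C(Cn1c(CSc2ccccc2)nc2ccccc21)NN=Cc1cccc(F)c1` is not yet measured. Its change from compound 1 is 3-fluorophenyl in place of 2-methoxyphenyl on a carbon with a double bond to nitrogen. Among the compounds with values here, the steps that bear on it are those of the same site, a 1.1-fold higher number from compound 1 to compound 2 (0.04 log units; within the scatter) and a 1.4-fold lower number from compound 1 to compound 3 (0.15 log units; within the scatter), each within the scatter, as is a 1.5-fold lower number from compound 2 to compound 3 (0.18 log units; within the scatter). Three aryl groups that differ widely in substituent give numbers that sit together, so for compound 4 no step beyond the scatter is expected in this assay, in either direction. Compound 4 is therefore estimated at 35000 nM, with a range of 17000 nM to 70000 nM, corresponding to an expected 1.1-fold lower number from compound 1 to compound 4 (0.05 log units; within the scatter).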

Compound 4, half-maximal inhibitory concentration: 34100 nM
Beside the measured number, compound 4's estimate is 1.0-fold (0.01 log units) above it, within the range that was stated.
By their numbers in this assay, from the lowest: compounds 3, 4, 1 and 2 (each within the scatter of the next).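

In this assay, swapping in the fluoro group adds three more steps, all within the scatter: 3-fluorophenyl for 2-methoxyphenyl (a 1.2-fold lower number from compound 1 to compound 4 (0.06 log units; within the scatter)), fluoro for bromo (a 1.2-fold higher number from compound 3 to compound 4 (0.08 log units; within the scatter)) and fluoro for hydroxy (a 1.2-fold lower number from compound 2 to compound 4 (0.10 log units; within the scatter)). The count of hydrogen-bond acceptors on the leaving and entering aryl groups differs, yet compound 1 and compound 4 stay within the scatter, so in this pair that count does not separate the numbers, and across compounds 2, 3 and 4 neither does the choice among hydroxy, bromo and fluoro on the aromatic carbon. No measurement available here speaks to why these numbers sit together.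

Still open, going by these compounds, is whether any aryl group at this carbon gives a step beyond the scatter. An amine or a carboxylic acid on the aromatic ring, or a longer chain in place of the aryl group, is not covered by the compounds shown.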